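The source may hold more compounds than are shown below. What is called first, only, known or untested is meant among the compounds shown, and "the series" means these compounds.

Of the compounds shown here, three share one core and have been measured in an assay on HEK293 cells for positive allosteric modulation of metabotropic glutamate receptor 2 (Rattus norvegicus), read by thallium flux, with a stated time of 2.5 min; a lower number here means a smaller maximal response, a higher number a larger maximal response. Compound 1 `Cc1c(OCCCCOc2ccc(C(=O)O)c(Cl)c2)ccc(C(=O)CC(C)C)c1O` gives 80.5% in this assay. Among the compounds with values here, compound 3 `Cc1c(OCCCCOc2cccc(C(=O)O)c2)ccc(C(=O)CC(C)C)c1O` gives 84.5%; the only change between them is 3-carboxyphenyl in place of 4-carboxy-3-chlorophenyl on an oxygen on a saturated carbon, and this gave a number 4 percentage points higher from compound 1 to compound 3 (within the scatter). Compound 2 `Cc1c(OCCCCOCOc2ccc(C(=O)O)cc2)ccc(C(=O)CC2CCCC2)c1O` gives 95.4%, the highest of the three; compound 3 sits nearest to it and compound 1 furthest, both gaps beyond the scatter, but compound 2 also differs from the others in more than one place, so no single step can be read from it.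

The next compound, compound 4 `Cc1cc(C(=O)O)ccc1OCCCCOc1ccc(C(=O)CC2CCCC2)c(O)c1C`, is drawn from compound 2 by the change (4-carboxy-2-methylphenyl in place of (4-carboxyphenoxy)methyl on an oxygen on a saturated carbon). Within the data shown here, none of the measured steps makes this same change; the only step on record, from compound 1 to compound 3, reshapes the carboxyphenyl group without touching the linking chain, and it stayed within the scatter. Compound 2 and compound 4 share the same ketone side chain, and the reference point is therefore compound 2. The expectation is a step of about a number 5.4 percentage points lower from compound 2 to compound 4 (within the scatter) in this assay, possibly a slight loss, but nothing clearly beyond the scatter. Compound 4 is estimated at 90%, within the range 74% to 103%.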

Compound 4, largest response reached (reported as percent of maximum), in percent of the reference or control that the assay uses: 84.6%
The estimate for compound 4 lay 5.4 percentage points above the measured number, within the range that was stated.
By their numbers in this assay, from the lowest: compounds 1, 3 and 4 (each within the scatter of the next); then compound 2.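

Replacing (4-carboxyphenoxy)methyl with 4-carboxy-2-methylphenyl on an oxygen on a saturated carbon gave a number 10.8 percentage points lower from compound 2 to compound 4 (beyond the scatter) in this assay, whereas the earlier change at this same place, a number 4 percentage points higher from compound 1 to compound 3 (within the scatter), did not move the number beyond the usual variation. The maximal response therefore does respond to what sits on this oxygen, although this single swap combines two edits: the methyl-and-oxygen link of the departing group is lost, and a methyl group arrives on the aromatic ring, so the drop cannot be assigned to either edit alone. Nothing available here offers an explanation for the lower number.

The compounds shown leave open how much of the step belongs to the link and how much to the methyl group, a question that a plain 4-carboxyphenyl group on the same oxygen, paired with the cyclopentyl ketone side chain of compound 2 and compound 4, would address. Also open, going by these compounds, is how the response would change with a longer chain in the linker or with a primary amide in place of the carboxylic acid.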